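Ring configuration change on the inactive benzylamide

The source may report more compounds than this note shows. Statements on the series, on what has been measured and on what is new or still open speak of the compounds shown alone.

The shared core of compound 1 `CCOC(=O)[C@]1(C(=O)Nc2ccccc2)C[C@H]1c1cc(OC)c(OC)c(OC)c1` carries an anilide; compound 2 `CCOC(=O)[C@]1(C(=O)NCc2ccc(C)cc2)C[C@H]1c1cc(OC)c(OC)c(OC)c1` carries a 4-methylbenzyl amide and compound 3 `CCOC(=O)[C@]1(C(=O)Nc2ccccc2Cl)C[C@H]1c1cc(OC)c(OC)c(OC)c1` a 2-chlorophenyl amide. In a functional assay on K562 cells (Homo sapiens) for cytotoxicity, read by MTT assay, with a stated time of 48 h (on this read-out lower numbers stand for stronger inhibition and higher numbers for weaker inhibition), compound 1 gives > 100000 nM, which is a limit of the assay rather than a number. In this assay compound 2 likewise gives > 100000 nM, again only a limit. Compound 3 gives 20700 nM in this assay. Hence the step that the two limits leave unreadable from compound 1 to compound 2 cannot be read, whereas an at least 4.8-fold lower number from compound 1 to compound 3 (0.68 log units; beyond the scatter) and an at least 4.8-fold lower number from compound 2 to compound 3 (0.68 log units; beyond the scatter) are readable in one direction only, with compound 2 standing at the limit of > 100000 nM in this assay, at which 2 of the 3 values shown sit.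

Compound 4 `CCOC(=O)[C@]1(C(=O)NCc2ccc(C)cc2)C[C@@H]1c1cc(OC)c(OC)c(OC)c1` differs from compound 2 only in configuration: the two compounds have the same atoms and bonds and differ only in configuration as drawn: 1 of 2 stereo elements differ; a stereocentre at a saturated ring carbon is drawn S in compound 2 and R in compound 4. Going by the values given here, none of the measured steps bears on a change at the saturated ring carbon; all three concern the amide substituent. Nothing in the series therefore speaks for a readable shift on changing the ring configuration while the 4-methylbenzyl amide stays. The expected step of a number no higher from compound 2 to compound 4 (the limit leaves the size open) is none beyond the scatter, and the result is expected to remain at the limit. Compound 4 is estimated at 100000 nM in this assay, within 30000 nM to 300000 nM.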

Compound 4, half-maximal inhibitory concentration: 20400 nM
For compound 4 the middle estimate is 4.9-fold (0.69 log units) above the measured one; measured number below the stated range.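

The saturated ring carbon now emerges as a position that matters in this assay, whereas every earlier step concerned the amide substituent: the change from S to R there gives an at least 4.9-fold lower number from compound 2 to compound 4 (0.69 log units; beyond the scatter). From the compounds shown here alone, the 4-methylbenzyl amide therefore does not by itself hold a compound at the limit, since with the R drawing it gives a measurable value, and the size of the step stays open on one side: the limit of > 100000 nM in this assay, at which 2 of the 4 values shown sit. No atom or bond enters or leaves in this step, so it can be assigned to the single stereocentre at that carbon: the fact that compounds 2 and 4 differ only in the configuration as drawn

Going by these compounds, whether the same change of drawing at the saturated ring carbon gives a comparable step with the anilide of compound 1 or the 2-chlorophenyl amide of compound 3 remains open, as does the contribution of the second stereo element, which is the same in compound 2 and compound 4. Also open, on these data alone, is whether the R series keeps its measurable value when the ethyl ester gives way to a carboxylic acid, or the 4-methyl group on the benzyl ring to a methoxy group.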